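A methyl on the aromatic nitrogen of compound 3

The source may report more compounds than this note shows. Statements on the series, on what has been measured and on what is new or still open speak of the compounds shown alone.

- compound 1 `Cn1c(/C=C/C(=O)c2cccc(N)c2)cc(Br)c1Br` gives 12400 nM
- compound 2 `O=C(/C=C/c1cc(Br)c(Br)[nH]1)c1ccc[nH]1` gives 72 nM
- compound 3 `O=c1cc(-c2cc(Br)c(Br)[nH]2)oc2ccccc12` gives >= 100000 nM

All three values come from a functional assay on MCF7 cells (Homo sapiens) for cytotoxicity, read by MTT assay, with stated times of 6 h and 48 h; on this read-out higher numbers stand for weaker inhibition and lower numbers for stronger inhibition. For compound 3, >= 100000 nM is a limit of the assay and not a number. Compound 4 `Cn1c(-c2cc(=O)c3ccccc3o2)cc(Br)c1Br` has methyl in place of hydrogen on an aromatic nitrogen. Among the measured compounds shown here, no measured pair shows this change alone, so only a small step is expected, with no direction beyond the scatter. Compound 1 also carries such a methyl and gives 12400 nM, so a measurable number remains possible. The expected change is an at least 1.4-fold lower number from compound 3 to compound 4 (0.15 log units; that floor lies within the scatter). The estimate for compound 4 is 70000 nM, with an expected range from 20000 nM to 100000 nM.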

Compound 4, half-maximal inhibitory concentration: >= 100000 nM
Compound 4 was reported as a limit (the forecaster's own chance of this, stated with the estimate: 55%); middle value at least 1.4-fold (0.15 log units) from the limit.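

Compound 3 and compound 4 both sit at a limit of the assay rather than at a number, so no step can be read between them: the limit of >= 100000 nM in this assay, at which 2 of the 4 values shown sit.

The compounds shown leave open what methyl in place of hydrogen on an aromatic nitrogen changes on its own.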